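One Amino-for-Chloro Swap, Tried on a Second Core

The source may hold more compounds than are shown below. What is called first, only, known or untested is meant among the compounds shown, and "the series" means these compounds.

Measured in a functional assay on COLO 205 cells (Homo sapiens) for cytotoxicity, read by sulforhodamine B assay, with a stated time of 48 h; on this read-out higher numbers stand for weaker inhibition of growth and lower numbers for stronger inhibition of growth:
Compound 1 `Nc1nc(Cl)c2ncn(Cc3ccc(CCl)cc3)c2n1` gives 13500 nM.
Compound 2 `ClCc1cccc(Cn2cnc3c(Cl)nc(Cl)nc32)c1` gives 5370 nM.
Compound 3 `ClCc1ccc(Cn2cnc3c(Cl)nc(Cl)nc32)cc1` gives > 100000 nM, which is a limit of the assay rather than a number.

Of the two numbers given outright, compound 2 has the lower one, and its gap to compound 1 is beyond the usual scatter. Compound 3 and compound 1 differ in one place, (amino in place of chloro on an aromatic carbon), and this change gave an at least 7.4-fold lower number from compound 3 to compound 1 (0.86 log units; beyond the scatter). The true size of that step is only bounded because compound 3 sits at the limit of > 100000 nM in this assay, at which 1 of the 3 values shown sits. Compound 2 and compound 3 are built from the same atoms joined differently; the difference between the two cores is not broken down here.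

Compound 4 `Nc1nc(Cl)c2ncn(Cc3cccc(CCl)c3)c2n1` is compound 2 with the same change applied, (amino in place of chloro on an aromatic carbon). If the change works on the core of compound 2 as it did from compound 3 to compound 1, the expected step is a 1.8-fold lower number from compound 2 to compound 4 (0.25 log units; within the scatter); this expectation rests on an at least 7.4-fold lower number from compound 3 to compound 1 (0.86 log units; beyond the scatter) and on compound 2 standing at 5370 nM. Compound 4 is therefore estimated at about 3000 nM, most likely between 700 nM and 15000 nM.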

Compound 4, concentration for total growth inhibition: 27500 nM
The estimate for compound 4 lay 9.2-fold (0.96 log units) below the measured number, outside the stated range (above it).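

Putting amino in place of chloro on an aromatic carbon gave a 5.1-fold higher number from compound 2 to compound 4 (0.71 log units; beyond the scatter) in this assay, which means weaker inhibition of growth. The same change therefore ran in opposite directions on the two cores, and the gap between the two steps is larger than chance scatter would explain: the same change on two cores in this assay, an at least 7.4-fold lower number (0.86 log units; beyond the scatter) from compound 3 to compound 1 and a 5.1-fold higher number (0.71 log units; beyond the scatter) from compound 2 to compound 4, at least 37-fold (1.57 log units) apart, beyond the scatter of two such steps

On these data alone, compound 3 gives > 100000 nM, which is a limit of the assay and not a number, so the full size of its step stays unknown even though its direction is clear. These two cores show that the effect of this change cannot simply be carried from one core to the other, but they do not show why the cores differ or what the change would do on a third core.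

The compounds shown leave open whether a methoxy or a dimethylamino group in the same place would behave like amino on both cores. They also leave open how compound 1 and compound 4 would respond if a hydroxymethyl group replaced the chloromethyl group.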